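The source may hold more compounds than are shown below. What is called first, only, known or untested is meant among the compounds shown, and "the series" means these compounds.

Measured so far, in a functional assay on MCF7 cells (Homo sapiens) for cytotoxicity, tested at 10 uM; a higher number here means more inhibition at the concentration tested (going by the name of the read-out), a lower number less inhibition:

compound 1 `O=Cc1c(-c2ccccc2)sc2ccccc12` gives 51%
compound 2 `N#Cc1c(-c2ccc(Cl)cc2)sc2ccccc12` gives 27%
compound 3 `N#Cc1c(-c2cccc(Cl)c2)sc2ccccc12` gives 36%

Among these three numbers compound 3 stands second highest. Its nearest neighbour is compound 2, whose value is lower by an amount that lies within the usual scatter of this kind of measurement, so the two cannot be told apart with confidence. The furthest is compound 1, whose value is higher by an amount beyond the scatter, so compound 1 does stand clearly above compound 3 in this assay.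

The next compound, compound 4 `N#Cc1c(-c2ccccc2)sc2ccccc12`, has not yet been measured in this assay. It differs from compound 3 in one place: hydrogen in place of chloro on an aromatic carbon. For the measured compounds named here, nothing measured so far shows what this kind of change does here, since no pair of measured compounds differs only in this way. Compound 2 and compound 3, which carry the chloro group in different places, sit within the scatter of each other.

Given that, the step from compound 3 to compound 4 is expected to be small, as expressed by a number 3 percentage points lower from compound 3 to compound 4 (within the scatter), and not clearly beyond the scatter in either direction. Compound 4 is therefore estimated to give 33% in this assay, with a range from 15% to 52%.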

Compound 4, a percentage reported as inhibition, at one concentration (the size of the read-out at that concentration, not a potency): 51%
Compound 4: middle estimate off by 18 percentage points, on the low side; the range from low to high includes it.
By their numbers in this assay, from the lowest: compounds 2 and 3 (each within the scatter of the next); then compounds 1 and 4 (each within the scatter of the next).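

In this assay hydrogen in place of chloro on an aromatic carbon now has a measured effect: the change gives a number 15 percentage points higher from compound 3 to compound 4 (beyond the scatter) with the chloro group meta to a large group, and a number 24 percentage points higher from compound 2 to compound 4 (beyond the scatter) with the chloro group in its other place on the ring, so both compounds that carry chloro sit clearly lower than the one without it. Cyano in place of formyl on an aromatic carbon, with no chloro group present, gives no change at the digits printed from compound 1 to compound 4 (within the scatter) and so shows that these two groups cannot be told apart in this read-out. No other kind of measurement is at hand that would explain either result.

The compounds shown leave open whether the lower number belongs to chloro alone or would also come with a fluoro group, a methoxy group or an amine on that same carbon. They also leave open whether cyano and formyl stay level once a chloro group is on the ring, and whether a carboxylic acid or an amide in their place would keep the number reached here.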